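This account rests on a few compounds, and the source may have more. Where it says the series, first, only, none or still open, it means among the compounds named here.

Measured in a functional assay (plasma) for inhibition, with Homo sapiens as the target; on this read-out lower numbers stand for stronger inhibition and higher numbers for weaker inhibition:
- compound 1 `O=C(O)CCC/C=C\C[C@H]1/C(=N/OC(c2ccccc2)c2ccccc2)CC[C@@H]1NS(=O)(=O)c1ccc(Cl)cc1`: 17000 nM
- compound 2 `O=C(O)CCC/C=C\C[C@@H]1[C@@H](NS(=O)(=O)c2ccc(F)cc2)CC[C@@H]1O`: 640 nM
- compound 3 `O=C(O)CCC/C=C\C[C@H]1C(=O)CC[C@@H]1NS(=O)(=O)c1ccc(Cl)cc1`: 640 nM

In this assay, compound 2 at 640 nM stands level with compound 3 at 640 nM. Together they hold the lowest of the three numbers, and compound 1 at 17000 nM lies far higher, beyond the scatter.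

Compound 4 `O=C(O)CCC/C=C\C[C@@H]1[C@@H](NS(=O)(=O)c2ccc(Cl)cc2)CC[C@@H]1O` has chloro in place of fluoro on an aromatic carbon of compound 2 (chloro in place of fluoro on an aromatic carbon). Going by the values given here, no measured pair shows this change alone. Compound 3 also carries a 4-chlorophenyl and gives 640 nM, although its core differs, so no shift beyond the scatter is expected. The estimated change is a 1.3-fold lower number from compound 2 to compound 4 (0.11 log units; within the scatter). For compound 4 the expected value is 500 nM, with an estimated range of 180 nM to 1400 nM.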

Compound 4, half-maximal inhibitory concentration: 190 nM
Compound 4: the middle estimate sits 2.6-fold (0.42 log units) above what was measured, within the range that was stated.
By their numbers in this assay, from the lowest: compound 4; then compounds 2 and 3 (each within the scatter of the next); then compound 1.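

Putting chloro in place of fluoro on the aromatic ring, with the rest of the molecule unchanged, gives a 3.4-fold lower number from compound 2 to compound 4 (0.53 log units; beyond the scatter) in this assay and so shows that this position responds to the choice of halogen. Compound 3 carries the same 4-chlorophenyl on a different core, so it could not isolate this change. Nothing available explains the step. As far as these compounds go, whether a bromo or a methoxy group at this position would lower the number further remains open, as does whether the same swap would have a similar effect on the core of compound 3.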